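Pyrazole carbamates: cyano substitution on the five-membered ring

This account rests on a few compounds, and the source may have more. Where it says the series, first, only, none or still open, it means among the compounds named here.

For the measured compounds named here, compound 2 `O=C(N1CCCN(Cc2ccc(OCc3ccccc3)cc2)CC1)n1cccn1` carries the bare pyrazole on the shared carbamate core and stands lowest of the two numbers measured so far; in an assay on membranes from brain for binding affinity to Monoacylglycerol lipase ABHD6 (Mus musculus), read by fluorescence, with stated times of 1 h and 30 min (on this read-out lower numbers stand for stronger inhibition and higher numbers for weaker inhibition), compound 2 gives 960 nM. Going by the values given here, its only neighbour is compound 1 `Cc1cnn(C(=O)N2CCCN(Cc3ccc(OCc4ccccc4)cc3)CC2)c1`, which carries a methyl on the ring carbon and in this assay gives 9500 nM. Among the compounds with values here, the one step recorded, a 9.9-fold lower number from compound 1 to compound 2 (1.00 log units; beyond the scatter), shows that removing that methyl lowered the number modestly.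

Compound 3 `N#Cc1cnn(C(=O)N2CCCN(Cc3ccc(OCc4ccccc4)cc3)CC2)c1` is the next variation: cyano in place of hydrogen on an aromatic carbon. Placed in words, this is cyano in place of hydrogen on an aromatic carbon, at the same ring position where compound 1 carried its methyl. Within the data shown here, the only step that bears on it is the methyl-to-hydrogen step, a 9.9-fold lower number from compound 1 to compound 2 (1.00 log units; beyond the scatter), which ran the other way; a cyano is not a methyl, so the size of any change is uncertain, but a substituent at this carbon has so far raised the number. The expectation for compound 3 is therefore a step of a 2.6-fold higher number from compound 2 to compound 3 (0.42 log units; beyond the scatter) in this assay, toward a higher number. Compound 3 is estimated at 2500 nM, within a range of 700 nM to 9000 nM.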

Compound 3, half-maximal inhibitory concentration: 85 nM
The estimate for compound 3 lay 29-fold (1.47 log units) above the measured number, and the stated range ends above it.
By their numbers in this assay, from the lowest: compound 3; then compound 2; then compound 1.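

The 4-cyano-1H-pyrazol-1-yl group of compound 3 shows that a substituent on this aromatic carbon, two ring bonds from the ring nitrogen, need not raise the number: in this assay the change from hydrogen to cyano gives an 11-fold lower number from compound 2 to compound 3 (1.05 log units; beyond the scatter) and so runs opposite to the step seen on removing methyl. Read at the same carbon, the exchange of methyl for cyano gives a 110-fold lower number from compound 1 to compound 3 (2.05 log units; beyond the scatter) with the rest of the structure unchanged, so the identity of this one group accounts for the whole spread among the three compounds. No measurement at hand bears on why cyano and methyl part in direction at this carbon.

As far as these compounds go, whether the lower number is particular to cyano or would also appear with another group on this carbon, such as a chlorine atom, a carboxylic acid or a methyl ester, remains open. Also open, from the compounds shown here alone, is whether the step from hydrogen to cyano keeps its direction and size when the shared core is changed elsewhere.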